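This account rests on a few compounds, and the source may have more. Where it says the series, first, only, none or still open, it means among the compounds named here.

Compound 1, `N#Cc1c(-c2ccc(Br)cc2)nc2cnccc2c1NCC(N)=O`: 148 nm/s
Compound 2, `CC[C@@H](Nc1c(C#N)c(-c2ccc(Br)cc2)nc2cnccc12)C(N)=O`: 202 nm/s
Compound 3, `CN(CC(N)=O)c1c(C#N)c(-c2ccc(Br)cc2)nc2cnccc12`: 206 nm/s

These three compounds share one core and were measured in an ADME assay on Caco-2 cells (Homo sapiens) for permeability, read by LC-MS, in the apical to basolateral direction, with a stated time of 2 h, tested at 2 uM; on this read-out higher numbers stand for higher permeability and lower numbers for lower permeability. Compound 2 gives 202 nm/s, the second highest of the three; its nearest neighbour is compound 3, a 1.0-fold higher number from compound 2 to compound 3 (0.01 log units; within the scatter), and its furthest is compound 1, a 1.4-fold higher number from compound 1 to compound 2 (0.14 log units; within the scatter). Compound 4 is `CC[C@@H](Nc1c(C#N)c(-c2ccc(-c3ccc(OC)cc3)cc2)nc2cnccc12)C(N)=O`; the change from compound 2 is 4-methoxyphenyl in place of bromo on an aromatic carbon. Within the data shown here, none of the measured steps touches this position: a 1.4-fold higher number from compound 1 to compound 2 (0.14 log units; within the scatter), a 1.4-fold higher number from compound 1 to compound 3 (0.14 log units; within the scatter) and a 1.0-fold higher number from compound 2 to compound 3 (0.01 log units; within the scatter) all concern the amine side chain, and all lie within the scatter. Among the measured compounds shown here, there is therefore no direct precedent, and the step from compound 2 to compound 4 is expected to be a 1.3-fold lower number from compound 2 to compound 4 (0.10 log units; within the scatter). Compound 4 is estimated at 160 nm/s, within 70 nm/s to 350 nm/s.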

Compound 4, apparent permeability: 114 nm/s
Compound 4: middle estimate off by 1.4-fold (0.15 log units), on the high side, within the range that was stated.
By their numbers in this assay, from the lowest: compounds 4, 1, 2 and 3 (each within the scatter of the next).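

In this assay, among these compounds, the change of 4-methoxyphenyl in place of bromo gives a 1.8-fold lower number from compound 2 to compound 4 (0.25 log units; within the scatter) on the shared core, the first reading at this position. A far larger group, bringing a second six-membered aromatic ring of carbon only and a hydrogen-bond acceptor, therefore leaves the number within the scatter, as the amine side-chain steps did. No measurement shown here accounts for the size of this step. Still open, from the compounds shown here alone, is how a carboxylic acid or an amine on the added ring would read. A plain phenyl in place of bromo would also show whether the methoxy group matters at all.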